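The source may report more compounds than this note shows. Statements on the series, on what has been measured and on what is new or still open speak of the compounds shown alone.

Of the compounds shown here, three sharing one core have been tested in a functional assay on MDA-MB-231 cells (Homo sapiens) for antiproliferative activity, read by sulforhodamine B assay, with a stated time of 48 h; a lower number here means a stronger inhibitor of growth, a higher number a weaker inhibitor of growth. Compound 1 `O=C1COc2ccccc2N1CCCn1cc(-c2ccccc2)nn1` gives 4900 nM in this assay. Compound 2 `Cc1ccc(-c2cn(CCCN3C(=O)COc4ccccc43)nn2)cc1` gives 1120 nM, and compound 3 `CCCc1cn(CCCN2C(=O)COc3ccccc32)nn1` gives 1100 nM. Compound 2 thus sits well apart from compound 1, the step being a 4.4-fold lower number from compound 1 to compound 2 (0.64 log units; beyond the scatter), while its number and that of compound 3 cannot be told apart, as a 1.0-fold lower number from compound 2 to compound 3 (0.01 log units; within the scatter) shows. Compound 4 `O=C1COc2ccccc2N1CCCn1cc(C2(O)CCCCC2)nn1` has not yet been measured. It differs from compound 2 in one place: 1-hydroxycyclohexyl in place of 4-methylphenyl on an aromatic carbon. The step that bears most on this change is the swap of an aromatic group for a chain, a 1.0-fold lower number from compound 2 to compound 3 (0.01 log units; within the scatter); the related swap from compound 1 gave a 4.5-fold lower number from compound 1 to compound 3 (0.65 log units; beyond the scatter). In both, a non-aromatic group in place of an aromatic one went with an equal or lower number. For the measured compounds named here, the entering group also carries a hydrogen-bond donor, which no measured compound has, so nothing here speaks to that part directly. A step of a 1.8-fold higher number from compound 2 to compound 4 (0.25 log units; within the scatter) is therefore expected, within or only slightly beyond the scatter toward a weaker inhibitor. Compound 4 is estimated at 2000 nM, with a range from 700 nM to 6000 nM.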

Compound 4, concentration for 50% growth inhibition: 1200 nM
Compound 4: middle estimate off by 1.7-fold (0.22 log units), on the high side; the measured number falls inside the stated range.
By their numbers in this assay, from the lowest: compounds 3, 2 and 4 (each within the scatter of the next); then compound 1.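

At this carbon of the five-membered aromatic ring, a group with a hydrogen-bond donor proves compatible with activity in this assay: a 1.1-fold higher number from compound 2 to compound 4 (0.03 log units; within the scatter) and a 1.1-fold higher number from compound 3 to compound 4 (0.04 log units; within the scatter) are both within the scatter, so 1-hydroxycyclohexyl cannot be told apart from 4-methylphenyl or propyl. Only phenyl stands apart among the groups shown, as a 4.1-fold lower number from compound 1 to compound 4 (0.61 log units; beyond the scatter) is beyond the scatter and now joins two earlier steps of similar size, although 4-methylphenyl shows that an aromatic ring alone does not go with the higher number. Nothing measured here explains why these three groups match or why phenyl differs.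

On these data alone, whether the hydroxyl matters in itself stays open, since plain cyclohexyl would be the direct comparison. Also open, as far as these compounds go, is how an amine, a carboxylic acid or a longer chain would behave at this carbon.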